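The source may report more compounds than this note shows. Statements on the series, on what has been measured and on what is new or still open speak of the compounds shown alone.

Measured compounds:
compound 1, `COC(=O)c1c(-c2ccc([N+](=O)[O-])cc2)oc2ccccc2c1=O`: > 25 ug/mL
compound 2, `COC(=O)c1c(-c2ccc(N)cc2)oc2ccccc2c1=O`: > 25 ug/mL
compound 3, `O=c1cc(-c2ccc([N+](=O)[O-])cc2)oc2ccc(O)cc12`: 21 ug/mL

All three were tested in a functional assay on SK-MEL cells (Homo sapiens) for cytotoxicity, read by MTT assay, with a stated time of 6 days; on this read-out lower numbers stand for an effect already at smaller amounts and higher numbers for an effect only at larger amounts of compound. For compound 1 the value > 25 ug/mL is a limit of this assay, not a number. For compound 2 the value > 25 ug/mL is likewise a limit. Among the compounds with values here, compound 3 gives 21 ug/mL in this assay , the only number among the three. Between compound 1 and compound 2 the change is amino in place of nitro on an aromatic carbon; the step that the two limits leave unreadable from compound 1 to compound 2 cannot be sized because both values sit at the limit of > 25 ug/mL in this assay, at which 2 of the 3 values shown sit.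

Compound 4, `Nc1ccc(-c2cc(=O)c3cc(O)ccc3o2)cc1`, has not yet been measured. It differs from compound 3 by amino in place of nitro on an aromatic carbon, the same change as from compound 1 to compound 2, with the place described in identical words. How the core of compound 3 differs from the core of compound 1 is not broken down here.

Since the earlier step gave no readable size, the expectation for compound 4 rests only on compound 3 giving 21 ug/mL. For compound 4 the expected step is a 1.0-fold higher number from compound 3 to compound 4 (0.02 log units; within the scatter), near no change. Compound 4 is therefore estimated at 22 ug/mL in this assay , between 10 ug/mL and 50 ug/mL, with a real chance that only a limit is reported.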

Compound 4, concentration for half-maximal effect: 2.03 ug/mL
Estimate against measurement, compound 4: 11-fold (1.03 log units) above; the measured number lies below the stated range.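

Amino in place of nitro on an aromatic carbon gives a 10-fold lower number from compound 3 to compound 4 (1.01 log units; beyond the scatter) in this assay, so on the core of compound 3 this change has a large effect on the read-out. The same change on the core of compound 1 leaves no readable step, because compound 1 and compound 2 both sit at a limit and not at a number: the limit of > 25 ug/mL in this assay, at which 2 of the 4 values shown sit. The large step is therefore shown on one core only, and the data neither confirm nor rule out that it carries over to the core of compound 1.

The compounds shown leave open whether the step belongs to amino in particular or would also appear with another group in its place, such as dimethylamino, acetamido or a carboxylic acid. They also leave open which of the differences between the core of compound 1 and the core of compound 3 matters, as no compound shown separates them.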